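This account rests on a few compounds, and the source may have more. Where it says the series, first, only, none or still open, it means among the compounds named here.

Compound 1 `CCN(CC)Cc1ccc2nc(NC(=O)N/N=C(\C)c3cnccn3)sc2c1` and compound 2 `C/C(=N\NC(=O)Nc1nc2ccc(CN3CCC(C)CC3)cc2s1)c1cnccn1` are built on one core, while compound 3 `CCN(CC)Cc1ccc(NC(=O)NN=C(c2ccccn2)c2ccccn2)cc1` carries a second core; how the two cores differ is not broken down here. In a functional assay on U-937 cells (Homo sapiens) for antiproliferative activity, read by CCK-8 assay, with a stated time of 24 h (a lower number here means a stronger inhibitor, a higher number a weaker inhibitor), compound 1 gives > 40000 nM, which is a limit of the assay rather than a number. Compound 2 likewise gives only a limit in this assay, namely > 40000 nM. The change from compound 1 to compound 2 is 4-methylpiperidin-1-yl in place of diethylamino on a saturated chain carbon bound to an aromatic carbon, and it yields a step that the two limits leave unreadable from compound 1 to compound 2. Compound 3 also returns a limit in this assay, > 40000 nM. Compound 4 `CC1CCN(Cc2ccc(NC(=O)NN=C(c3ccccn3)c3ccccn3)cc2)CC1` repeats that same change on the second core: 4-methylpiperidin-1-yl in place of diethylamino on a saturated chain carbon bound to an aromatic carbon. The place of the change is worded identically in both cases, so this is the same change made twice among the compounds shown. Among the compounds with values here, the expected step in this assay is a step that the limit leaves unreadable from compound 3 to compound 4, since every value so far sits at the limit of > 40000 nM in this assay, at which 3 of the 3 values shown sit. For compound 4 the estimate in this assay is 60000 nM, expected to fall between 20000 nM and 200000 nM.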

Compound 4, half-maximal inhibitory concentration: > 40000 nM
Compound 4 gave a limit, no number (the forecaster's own chance of this, stated with the estimate: 85%); the middle value lies beyond the limit too.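

No step can be read between compound 3 and compound 4, since both stop at a limit of the assay rather than a number: the limit of > 40000 nM in this assay, at which 4 of the 4 values shown sit.

The compounds shown leave open whether 4-methylpiperidin-1-yl in place of diethylamino shifts activity at all in this assay, on either core, and whether the shift would match between the two cores.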